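A few compounds are considered here, and "the series" means these few. Any claim that something is new, unique, unknown or untested is made for them only; others in the source may bear on it.

Measured so far in an ADME assay for permeability, using PAMPA, with a stated time of 30 min, at pH 7.4; a lower number here means that the compound crosses the layer more slowly, a higher number that the compound crosses the layer faster:
compound 1 `COc1ccccc1Oc1ccc2c(NCCCNCc3ccco3)ccnc2c1`, where compound 1 gives 317 10^-6 cm/s
compound 2 `COc1cccc(CNCCCNc2ccnc3cc(Cc4ccccc4)ccc23)c1O`, where compound 2 gives 23 10^-6 cm/s
compound 3 `COc1cccc(CNCCCNc2ccnc3cc(-c4ccc(F)cc4)ccc23)c1O`, where compound 3 gives 237 10^-6 cm/s

Compound 3 sits among the higher numbers, within the scatter of compound 1 and far from compound 2; that gap is shown directly by a 10-fold higher number from compound 2 to compound 3 (1.01 log units; beyond the scatter). Compound 4 `COc1ccccc1Oc1ccc2c(NCCCNCc3cccc(OC)c3O)ccnc2c1` is not yet measured. (2-methoxyphenoxy in place of 4-fluorophenyl on an aromatic carbon). Among the compounds with values here, the only measured step at this aromatic carbon swaps a different pair of groups, so it bears only loosely on the present change. Compound 1 already carries 2-methoxyphenoxy at this position and gives 317 10^-6 cm/s, close to compound 3. Compound 4 is therefore expected to stay near compound 3, with a 1.1-fold higher number from compound 3 to compound 4 (0.02 log units; within the scatter) expected to remain within the scatter. The estimate for compound 4 in this assay is 250 10^-6 cm/s, range 120 10^-6 cm/s to 500 10^-6 cm/s.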

Compound 4, apparent permeability: 317 10^-6 cm/s
The estimate for compound 4 lay 1.3-fold (0.10 log units) below the measured number; the range from low to high includes it.
By their numbers in this assay, from the lowest: compound 2; then compounds 3, 1 and 4 (each within the scatter of the next).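

In this assay, 2-methoxyphenoxy and 4-fluorophenyl on this aromatic carbon read alike (a 1.3-fold higher number from compound 3 to compound 4 (0.13 log units; within the scatter)), while benzyl stands well apart (a 14-fold higher number from compound 2 to compound 4 (1.14 log units; beyond the scatter)). Within the data shown here, the first measured step on the saturated chain carbon bound to an amine nitrogen shows that 2-hydroxy-3-methoxyphenyl and furan-2-yl also read alike (no change at the digits printed from compound 1 to compound 4 (within the scatter)). No available evidence gives a cause for these steps.

Still open, from the compounds shown here alone, is whether a carboxylic acid or an amine on this aromatic carbon would stay with compound 4 or fall toward compound 2. Going by these compounds, a longer chain in the shared core also remains open.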